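This account rests on a few compounds, and the source may have more. Where it says the series, first, only, none or still open, it means among the compounds named here.

Measured compounds:
- Compound 1, `COc1cc(N(CC2CC2)c2ccc(Cl)c3ccccc23)cnc1C(=O)CCCC(=O)O`: "not determined" (no result reported) in an assay on isolated protein for inhibition of leukotriene C4 synthase (Homo sapiens), read by LC-MS, with stated times of 45 min and 20 min; a lower number here means a stronger inhibitor, a higher number a weaker inhibitor
- Compound 2, `COc1cc(N(CC2CC2)c2cccc(C(F)(F)F)c2)cnc1C(=O)[C@H]1C[C@@H]1C(=O)O`: 52.4 nM in this assay
- Compound 3, `COc1cc(N(CC(C)(C)O)c2cccc(C(F)(F)F)c2)cnc1C(=O)[C@H]1C[C@@H]1C(=O)O`: "not determined" (no result reported) in this assay

All three share the same core, a pyridine bearing a methoxy group and a ketone linked to an acid-bearing fragment, with a nitrogen carrying two substituents. Compound 2 is the only one of the three with a number: in this assay compound 2 gives 52.4 nM. Compound 3 stands at "not determined" (no result reported) in this assay. Among the compounds with values here, compound 1 likewise stands at "not determined" (no result reported) in this assay, so there is no measured step to lean on here.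

Compound 4, `COc1cc(N(Cc2ccc(F)cc2)c2cccc(C(F)(F)F)c2)cnc1C(=O)[C@H]1C[C@@H]1C(=O)O`, is the next one to be measured. It differs from compound 3 in one place: 4-fluorophenyl in place of 1-hydroxy-1-methylethyl on a saturated chain carbon bound to a nitrogen on an aromatic ring. Because no step between measured compounds is shown, the size and direction of this change can only be guessed. The one reference, compound 2, has a cyclopropylmethyl group on the same nitrogen and gives 52.4 nM in this assay. A 4-fluorobenzyl group on that nitrogen is expected to give a result of similar order, with a modest spread either way rather than a large shift. Compound 4 is expected to come out near 40 nM in this assay, with a likely range from 10 nM to 160 nM.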

Compound 4, half-maximal inhibitory concentration: 157 nM
Estimate against measurement, compound 4: 3.9-fold (0.59 log units) below, within the range that was stated.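

Replacing cyclopropyl with 4-fluorophenyl on a saturated chain carbon bound to a nitrogen on an aromatic ring gives, in this assay, a 3.0-fold higher number from compound 2 to compound 4 (0.48 log units; beyond the scatter). Since a higher number means a weaker inhibitor, this first readable change at this position shows that the swap costs some inhibition, in a modest step, but does not abolish it: compound 4, with its six-membered aromatic ring at this place, still gives a measurable 157 nM. Nothing among the data shown explains why the number rises.

As far as these compounds go, the steps involving compound 1 or compound 3 cannot be read, so the effect of the 2-hydroxy-2-methylpropyl group on the same nitrogen remains unknown. An unsubstituted benzyl group at this place would separate the contribution of the ring from that of the fluorine, while a chain ending in an amine would test a quite different kind of group, and the compounds shown speak to neither.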